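Swapping one ring for another: expected tolerance of compound 4

The compounds below may be only part of what the source reports. "The series", "measured", "known", "first", "only" and "open" are said of these compounds alone.

Of the compounds shown here, three sharing one core have been tested in an ADME assay on cells (T-cell, Mus musculus, strain BALB/c) for cytotoxicity, read by MTT assay, with a stated time of 48 h; a lower number here means that less compound is tolerated, a higher number that more compound is tolerated. Compound 2 `COC(=O)c1ccc(C)cc1OC(=O)COc1cc(O)c2c(=O)cc(-c3ccccc3)oc2c1` gives 250000 nM, the lowest of the three numbers. Compound 3 `COC(=O)c1cccc(C)c1OC(=O)COc1cc(O)c2c(=O)cc(-c3ccccc3)oc2c1` gives 299000 nM, and the step of a 1.2-fold higher number from compound 2 to compound 3 (0.08 log units; within the scatter) shows that this kind of exchange made no difference beyond the scatter. Compound 1 `COC(=O)c1c(Br)cc(Br)cc1OC(=O)COc1cc(O)c2c(=O)cc(-c3ccccc3)oc2c1` gives 398000 nM; its value and that of compound 2 lie within the scatter of each other, so no order between them can be claimed.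

Compound 4 `COC(=O)c1c(Cl)cccc1OC(=O)COc1cc(O)c2c(=O)cc(-c3ccccc3)oc2c1` differs from compound 2 in one place: a group of 11 heavy atoms (8 carbon, 2 oxygen, 1 chlorine; one six-membered aromatic ring of carbon only) in place of a group of 11 heavy atoms (9 carbon, 2 oxygen; one six-membered aromatic ring of carbon only), on an oxygen next to a carbonyl group. Within the data shown here, the only measured step of the same kind is the one from compound 2 to compound 3, which stayed within the scatter. Among the measured compounds shown here, no measured compound carries the 3-chloro-2-(methoxycarbonyl)phenyl group, so what the chlorine contributes is not known from these data. On this basis the expected step of a 1.1-fold higher number from compound 2 to compound 4 (0.05 log units; within the scatter) is none beyond the scatter. Compound 4 is therefore estimated at 280000 nM, with a range from 140000 nM to 560000 nM.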

Compound 4, half-maximal cytotoxic concentration: 366000 nM
Compound 4: middle estimate off by 1.3-fold (0.12 log units), on the low side, and the stated range covers the measured number.
By their numbers in this assay, from the lowest: compounds 2, 3, 4 and 1 (each within the scatter of the next).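

With the 3-chloro-2-(methoxycarbonyl)phenyl group on this oxygen next to a carbonyl group, this assay gives a 1.5-fold higher number from compound 2 to compound 4 (0.17 log units; within the scatter) and a 1.2-fold higher number from compound 3 to compound 4 (0.09 log units; within the scatter) as its two new steps. Among these compounds, the one earlier step at this place exchanged one group of carbon and oxygen for another, whereas these two bring in a group holding chlorine, and they too stay within the scatter. No separate measurement bears on these results.

Going by these compounds, all four compounds carry a ring with a methoxycarbonyl group at this place, so the effect of an amine or a free carboxylic acid in place of that group remains open. On these data alone, whether any exchange here can move the number beyond the scatter also remains open.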